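Notes on the step from compound 3 to compound 4

A few compounds are considered here, and "the series" means these few. Any claim that something is new, unique, unknown or untested is made for them only; others in the source may bear on it.

compound 1 `COc1ncc(-c2ccc3nccc(N4CCCC4)c3c2)cc1NS(=O)(=O)c1ccc(F)cc1F`: 3410 nM
compound 2 `COc1ncc(-c2ccc3nccc(-c4ccc(CN5CCN(C)CC5)cc4)c3c2)cc1NS(=O)(=O)c1ccc(F)cc1F`: 13.3 nM
compound 3 `COc1ncc(-c2ccc3nccc(-c4ccc(CN5CCN(C(C)C)CC5)cc4)c3c2)cc1NS(=O)(=O)c1ccc(F)cc1F`: 1.9 nM

In a functional assay on A549 cells (Homo sapiens) for cytotoxicity, read by MTT assay, with a stated time of 72 h (a higher number here means a weaker inhibitor, a lower number a stronger inhibitor), compound 3 gives the lowest number of the three. Its nearest neighbour is compound 2, from which it is reached by the step of a 7.0-fold lower number from compound 2 to compound 3 (0.85 log units; beyond the scatter). Going by the values given here, compound 1, which carries a pyrrolidinyl directly on the shared core in place of the aryl arm, gives a number far above both, and no single-point step to it is available.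

Compound 4 `COc1ncc(-c2ccc3nccc(-c4ccc(Cn5cncn5)cc4)c3c2)cc1NS(=O)(=O)c1ccc(F)cc1F` differs from compound 3 by 1H-1,2,4-triazol-1-yl in place of 4-isopropylpiperazin-1-yl on a saturated chain carbon bound to an aromatic carbon. Among the compounds with values here, the only measured step that bears on this place is the one from compound 2 to compound 3, and it shows that the group on the piperazine nitrogen alone moves this assay by a modest amount. The change to compound 4 is larger: the whole six-membered ring with its two nitrogens leaves and a five-membered aromatic ring with three nitrogens enters. Within the data shown here, no measured pair covers such an exchange, so the direction is inferred only from the sensitivity of this position seen in that one step. A weaker inhibitor than compound 3 is expected, with a wide range.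

For compound 4 the estimate in this assay is 30 nM, between 5 nM and 300 nM, which is an expected step of a 16-fold higher number from compound 3 to compound 4 (1.20 log units; beyond the scatter).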

Compound 4, half-maximal inhibitory concentration: 16 nM
Compound 4: middle estimate off by 1.9-fold (0.27 log units), on the high side; measured number inside the range.
By their numbers in this assay, from the lowest: compound 3; then compounds 2 and 4 (each within the scatter of the next); then compound 1.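

In this assay the step of an 8.4-fold higher number from compound 3 to compound 4 (0.93 log units; beyond the scatter) shows that the whole 4-isopropylpiperazin-1-yl group can leave this saturated chain carbon and a 1H-1,2,4-triazol-1-yl group can take its place at a real but modest cost, not a collapse towards the number of compound 1. The step of a 1.2-fold higher number from compound 2 to compound 4 (0.08 log units; within the scatter) is the more informative reading, as it places the 1H-1,2,4-triazol-1-yl group and the 4-methylpiperazin-1-yl group level in this assay, so a piperazine ring is not needed to reach this range, and among these three arms only the isopropyl-bearing one stands apart. The step of a 210-fold lower number from compound 1 to compound 4 (2.33 log units; beyond the scatter) then shows that the large distance from compound 1 survives without any piperazine, so it does not rest on that ring.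

From the compounds shown here alone, whether the isopropyl gain has any counterpart away from the piperazine stays open, as does the outcome with a morpholine, an imidazole or a dimethylamino group on the same chain carbon. The measurements at hand offer nothing that explains any of these steps.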